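From phenyl to 4-iodophenyl in compound 3

The source may hold more compounds than are shown below. What is called first, only, known or untested is meant among the compounds shown, and "the series" means these compounds.

Compound 1 `O=[N+]([O-])c1cccc(-c2nn(-c3ccccc3)cc2C(Nc2nc3ccc(Cl)cc3s2)c2c(O)ccc3ccccc23)c1` gives 19700 nM
Compound 2 `Oc1ccc2ccccc2c1C(Nc1nc2ccc(Cl)cc2s1)c1cn(-c2ccccc2)nc1-c1ccccc1` gives 36300 nM

In a functional assay on MCF7 cells (Homo sapiens) for antiproliferative activity, read by MTT assay, with a stated time of 48 h (on this read-out higher numbers stand for weaker inhibition and lower numbers for stronger inhibition), compound 2 gives 36300 nM and compound 1 lies within the usual scatter of it. The change from compound 2 to compound 3 `Oc1ccc2ccccc2c1C(Nc1nc2ccc(Cl)cc2s1)c1cn(-c2ccccc2)nc1-c1ccc(I)cc1` is iodo in place of hydrogen on an aromatic carbon and in words it is iodo in place of hydrogen on an aromatic carbon. Among the measured compounds shown here, the one measured step that also swaps hydrogen on an aromatic carbon is a 1.8-fold higher number from compound 1 to compound 2 (0.27 log units; within the scatter) and it stays within the scatter. No step beyond the scatter is therefore expected, and the estimated step is a 1.2-fold lower number from compound 2 to compound 3 (0.08 log units; within the scatter) in size. For compound 3 the expected value is 30000 nM with 12000 nM and 70000 nM as the ends of the estimated range.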

Compound 3, half-maximal inhibitory concentration: 65000 nM
For compound 3 the middle estimate is 2.2-fold (0.34 log units) below the measured one; low and high end bracket the measured number.
By their numbers in this assay, from the lowest: compounds 1, 2 and 3 (each within the scatter of the next, the first and the last beyond it).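

In this assay, iodo in place of hydrogen on the phenyl group, para to a large group, gives a 1.8-fold higher number from compound 2 to compound 3 (0.25 log units; within the scatter) and so stays within the scatter. Among the compounds shown here, the 4-iodophenyl group in place of 3-nitrophenyl gives a 3.3-fold higher number from compound 1 to compound 3 (0.52 log units; beyond the scatter) and is the only step here beyond the scatter, though it is modest. No available evidence explains why these numbers differ. Still open, on these data alone, is whether an amine or a carboxylic acid on this phenyl group would give a larger step. Also open, as far as these compounds go, is whether iodo elsewhere on this group would give the same number.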